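Bromo in Place of Iodo: A Step Expected Within Scatter

The source may hold more compounds than are shown below. What is called first, only, known or untested is meant among the compounds shown, and "the series" means these compounds.

Compound 1, `O=C1O/C(=C\Cn2cc(C(F)(F)F)c(=O)[nH]c2=O)C(OCc2ccccc2)=C1OCc1ccccc1`, in a functional assay on HEL cells (Homo sapiens) for cytotoxicity (on this read-out lower numbers stand for stronger inhibition and higher numbers for weaker inhibition), gives 1000 nM.
Compound 2, `O=C1O/C(=C\Cn2cc(I)c(=O)[nH]c2=O)C(OCc2ccccc2)=C1OCc1ccccc1`, in this assay gives 3000 nM.
Compound 3, `O=C1O/C(=C\Cn2ccc(=O)[nH]c2=O)C(OCc2ccccc2)=C1OCc1ccccc1`, in this assay gives 5000 nM.

Among these three numbers compound 2 holds the second highest. Its nearest neighbour is compound 3, and the step of a 1.7-fold higher number from compound 2 to compound 3 (0.22 log units; within the scatter) stays within the scatter of repeated measurements. Its furthest neighbour is compound 1, reached by the step of a 3.0-fold higher number from compound 1 to compound 2 (0.48 log units; beyond the scatter), which lies beyond the scatter. The step of a 5.0-fold higher number from compound 1 to compound 3 (0.70 log units; beyond the scatter) is also beyond the scatter.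

Compound 4, `O=C1O/C(=C\Cn2cc(Br)c(=O)[nH]c2=O)C(OCc2ccccc2)=C1OCc1ccccc1`, is not yet measured. It differs from compound 2 by bromo in place of iodo on an aromatic carbon.

Among the measured compounds shown here, no measured step exchanges one halogen for another. The closest comparison is compound 2 against compound 3, where removing the iodo altogether gave only a 1.7-fold higher number from compound 2 to compound 3 (0.22 log units; within the scatter), within the scatter. The larger steps from compound 1 involve the trifluoromethyl group and do not speak to this change. The step from compound 2 to compound 4 in this assay is therefore expected to be a 1.2-fold higher number from compound 2 to compound 4 (0.07 log units; within the scatter), not beyond the scatter in either direction. Compound 4 is estimated at 3500 nM, within a range of 1500 nM to 8000 nM.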

Compound 4, half-maximal inhibitory concentration: 3000 nM
Compound 4: middle estimate off by 1.2-fold (0.07 log units), on the high side, and the stated range covers the measured number.
By their numbers in this assay, from the lowest: compound 1; then compounds 2, 4 and 3 (each within the scatter of the next).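

In this assay, swapping one halogen for another on this aromatic carbon gives no change at the digits printed from compound 2 to compound 4 (within the scatter) and thus shows directly that iodo and bromo cannot be told apart here. Bromo in place of hydrogen gives a 1.7-fold lower number from compound 3 to compound 4 (0.22 log units; within the scatter) and so also stays within the scatter, while bromo in place of trifluoromethyl gives a 3.0-fold higher number from compound 1 to compound 4 (0.48 log units; beyond the scatter) and thereby leaves compound 1 apart from all three other compounds at this position. No supporting measurement is available to explain this pattern.

The compounds shown leave open whether the separation seen with trifluoromethyl is particular to that group or would also appear with a nitrile, a methyl or an amine on the same aromatic carbon. They also leave open whether a chloro or fluoro group would fall with bromo and iodo.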